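The source may hold more compounds than are shown below. What is called first, only, known or untested is meant among the compounds shown, and "the series" means these compounds.

Compound 1 `FC(F)(F)c1ccc(NCc2cn(-c3ccccc3)nc2-c2ccccc2)cc1`: 37000 nM
Compound 2 `Cc1ccc(-c2nn(-c3ccccc3)cc2CNc2ccc(C(F)(F)F)cc2)cc1`: 88000 nM
Compound 3 `Cc1ccc(NCc2cn(-c3ccccc3)nc2-c2ccc(Br)cc2)cc1`: > 100000 nM

Of the compounds shown here, three have so far been tested in an ADME assay on BHK-21 cells (Mesocricetus auratus) for cytotoxicity, read by MTT assay, with a stated time of 72 h; on this read-out higher numbers stand for lower toxicity in this test and lower numbers for higher toxicity in this test. Compound 1 gives 37000 nM, while compound 2 gives 88000 nM. For compound 3 the read-out is > 100000 nM, which is a limit of the assay and not a number; compound 3 sits at the limit of > 100000 nM in this assay, at which 1 of the 3 values shown sits.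

Compound 2 and compound 1 differ in one place only: hydrogen in place of methyl on an aromatic carbon. In this assay this step is a 2.4-fold lower number from compound 2 to compound 1 (0.38 log units; beyond the scatter). The difference between the cores of compound 2 and compound 3 is not broken down here.

Compound 4 `Brc1ccc(-c2nn(-c3ccccc3)cc2CNc2ccccc2)cc1` has not yet been measured. It differs from compound 3 by the same change: hydrogen in place of methyl on an aromatic carbon. Cut one bond further out, the change from compound 3 to compound 4 reads as (4-methylphenyl)amino to anilino, whereas the change from compound 2 to compound 1 reads as 4-methylphenyl to phenyl.

Given that the same change from compound 2 to compound 1 produced a 2.4-fold lower number from compound 2 to compound 1 (0.38 log units; beyond the scatter), a step of similar size is expected from compound 3 to compound 4, namely an at least 1.3-fold lower number from compound 3 to compound 4 (0.12 log units; that floor lies within the scatter). Since compound 3 is known only as a limit, > 100000 nM, the starting point is itself uncertain, and compound 4 may well also return a limit. The estimate for compound 4 in this assay is 75000 nM, with a likely range from 30000 nM to 200000 nM.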

Compound 4, half-maximal cytotoxic concentration: > 100000 nM
Compound 4 ended at the assay's limit (the forecaster's own chance of this, stated with the estimate: 45%); at least 1.3-fold (0.12 log units) between middle value and limit.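

Compound 4, like compound 3, returned a limit of the assay and not a number in this assay, so no step between the two can be read: the limit of > 100000 nM in this assay, at which 2 of the 4 values shown sit.

The compounds shown leave open whether hydrogen in place of methyl on an aromatic carbon gives, from compound 3 to compound 4, anything like a 2.4-fold lower number from compound 2 to compound 1 (0.38 log units; beyond the scatter).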